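A few compounds are considered here, and "the series" means these few. Any claim that something is new, unique, unknown or untested is made for them only; others in the source may bear on it.

Compound 1 `Nc1cc(N)c2nc(-c3ccccc3)c(Oc3ccc(Cl)c(Cl)c3)nc2c1` gives 25100 nM in a functional assay on OVCAR-5 cells (Homo sapiens) for inhibition, read by sulforhodamine B assay, with a stated time of 48 h; on this read-out lower numbers stand for stronger inhibition of growth and higher numbers for weaker inhibition of growth.
Compound 2 `CCOC(=O)[C@H](CCC(=O)O)NC(=O)c1ccc(Sc2nc3cc(N)cc(N)c3nc2-c2ccccc2)cc1` gives 60300 nM in this assay.
Compound 3 `COc1ccc(CNc2nc3cc(N)cc(N)c3nc2-c2ccccc2)cc1` gives 20900 nM in this assay.

Among these three numbers compound 1 holds the second highest. The values of compound 1 and compound 3 sit within the usual scatter of each other, so no order between them can be read, whereas compound 2 gives a higher number that lies beyond the scatter.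

Compound 4 `Nc1cc(N)c2nc(-c3ccccc3)c(Sc3ccc(F)cc3)nc2c1` has not been measured. It differs from compound 1 in one place: (4-fluorophenyl)sulfanyl in place of 3,4-dichlorophenoxy on an aromatic carbon. Among the compounds with values here, no measured pair shows this change, so nothing in the data tells its size or direction. The expected step of a 1.1-fold lower number from compound 1 to compound 4 (0.06 log units; within the scatter) is one that stays within the scatter. Compound 4 is estimated at 22000 nM, with a range from 7000 nM to 65000 nM.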

Compound 4, concentration for 50% growth inhibition: 19100 nM
The estimate for compound 4 lay 1.2-fold (0.06 log units) above the measured number; measured number inside the range.
By their numbers in this assay, from the lowest: compounds 4, 3 and 1 (each within the scatter of the next); then compound 2.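

Putting (4-fluorophenyl)sulfanyl in place of 3,4-dichlorophenoxy gives a 1.3-fold lower number from compound 1 to compound 4 (0.12 log units; within the scatter) in this assay and so shows that this aromatic carbon tolerates this exchange with no readable shift in growth inhibition. The linking atom and the halogens on the ring change together, so the step cannot separate their contributions. Nothing measured here explains the result.

On these data alone, whether this position also tolerates a group without an aromatic ring, such as a short alkyl chain or a morpholine, remains open.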